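Removing the ring nitrogen substituent in a pyrazoline series

This account rests on a few compounds, and the source may have more. Where it says the series, first, only, none or still open, it means among the compounds named here.

Compound 2 `CC(=O)N1N=C(c2ccccc2)CC1c1ccc(Cl)cc1` was measured in an assay for inhibition of cathepsin H (Capra hircus), read by colorimetric assay, with a stated time of 30 min (a higher number here means a weaker inhibitor, a lower number a stronger inhibitor), where compound 2 gives 9000 nM. Within the data shown here, of the two numbers available it is the higher, but its only neighbour, compound 1 `Clc1ccc(C2CC(c3ccccc3)=NN2c2ccccc2)cc1`, sits within the scatter of it: in this assay compound 1 gives 6250 nM, and the move a 1.4-fold higher number from compound 1 to compound 2 (0.16 log units; within the scatter) is an acetyl in place of a phenyl on the ring nitrogen. Compound 3 `Clc1ccc(C2CC(c3ccccc3)=NN2)cc1` takes that ring nitrogen one stage further: hydrogen in place of acetyl on an amine nitrogen in a ring, on the five-membered non-aromatic ring with 2 nitrogen. Among the measured compounds shown here, the single measured step that bears on this position, from phenyl to acetyl, did not leave the scatter, so the substituent on that nitrogen has so far made no recognisable difference. For compound 3 the expectation is therefore a step of a 1.1-fold lower number from compound 2 to compound 3 (0.05 log units; within the scatter), with no change beyond the scatter anticipated. Compound 3 is estimated at 8000 nM in this assay, within a range from 2500 nM to 25000 nM.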

Compound 3, half-maximal inhibitory concentration: 7000 nM
Compound 3: middle estimate off by 1.1-fold (0.06 log units), on the high side; low and high end bracket the measured number.
By their numbers in this assay, from the lowest: compounds 1, 3 and 2 (each within the scatter of the next).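

In this assay, the step from acetyl to hydrogen is a 1.3-fold lower number from compound 2 to compound 3 (0.11 log units; within the scatter), and the step from phenyl to hydrogen is a 1.1-fold higher number from compound 1 to compound 3 (0.05 log units; within the scatter). Phenyl, acetyl and hydrogen on the ring nitrogen therefore cannot be told apart in these three compounds, which extends the earlier comparison of two groups to a case with no group on that nitrogen at all. No measurement offers an explanation for this result.

On these data alone, whether a longer chain ending in an amine or a carboxylic acid on that nitrogen would give a step beyond the scatter remains open. Also open, as far as these compounds go, is whether replacing the 4-chlorophenyl group or the phenyl group, which all three compounds share, would do so.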